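A few compounds are considered here, and "the series" means these few. Any claim that something is new, unique, unknown or untested is made for them only; others in the source may bear on it.

Measured in a functional assay on SMMC-7721 cells (Homo sapiens) for cytotoxicity, read by MTT assay, with a stated time of 48 h; on this read-out higher numbers stand for weaker inhibition and lower numbers for stronger inhibition:
compound 1 `Cc1ccc2oc(-c3ccc(Cl)cc3)cc(=O)c2c1` gives "not determined" (no result reported)
compound 2 `O=c1cc(-c2ccc(Cl)cc2)oc2ccc(CN3CCCCC3)cc12` gives 16200 nM
compound 3 `CC[N+](CC)(CC)Cc1ccc2oc(-c3ccc(Cl)cc3)cc(=O)c2c1` gives "not determined" (no result reported)

Of these three compounds, which share one core, only compound 2 has a number, so it cannot be ranked against compound 1 or compound 3. Its value is the sole reference point in this series, and nothing can be said about whether it is strong or weak among its neighbours.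

The next compound, compound 4 `Nc1ccc(-c2cc(=O)c3cc(CN4CCCCC4)ccc3o2)cc1`, differs from compound 2 in one place (amino in place of chloro on an aromatic carbon). The 4-chlorophenyl of compound 2 thus becomes a 4-aminophenyl in compound 4. Among the measured compounds shown here, the data hold no pair of measured compounds that differ in one place, and so they give no precedent for this exchange or for any other.

With compound 2 at 16200 nM as the only anchor, no direction can be argued, and the expectation stays close to that value. The expected size of a 1.2-fold lower number from compound 2 to compound 4 (0.06 log units; within the scatter) is no greater than the usual scatter of repeated measurements. Compound 4 is estimated at 14000 nM within an expected range of 4000 nM to 45000 nM in this assay once it is tested.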

Compound 4, half-maximal inhibitory concentration: 3680 nM
Beside the measured number, compound 4's estimate is 3.8-fold (0.58 log units) above it, outside the stated range (below it).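

In this assay, the exchange of chloro for amino on the aromatic carbon gives the series its first readable step, a 4.4-fold lower number from compound 2 to compound 4 (0.64 log units; beyond the scatter). This shows that the read-out responds to the group at this place, para to a large group, even though the change swaps only one heavy atom for another and leaves the rest of compound 2 untouched. It also shows that the 4-aminophenyl, which adds one hydrogen-bond donor and one hydrogen-bond acceptor to the count, is compatible with a lower number here, although nothing at hand accounts for the size or direction of the step.

The compounds shown leave open whether this lower number is specific to amino or would also appear with another group at this place, such as hydroxyl, methoxy or dimethylamino, and how plain hydrogen would compare with both chloro and amino. Among the compounds shown here, they also leave open whether the same exchange would give a step of similar size with a side chain other than the one shared by compound 2 and compound 4.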